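Replacing the acyl group on compound 1

The compounds below may be only part of what the source reports. "The series", "measured", "known", "first", "only" and "open" are said of these compounds alone.

Compound 1 `CCOc1cc(NC(=O)C2(NC(=O)c3ccc4c(C5CCCC5)c(-c5ncc(Cl)cn5)n(C)c4c3)CCC2)ccc1/C=C/C(=O)OC(=O)C[C@H](O)C(=O)O`: 5.57 h
Compound 2 `CCOc1cc(NC(=O)C2(NC(=O)c3ccc4c(C5CCCC5)c(-c5ncc(Cl)cn5)n(C)c4c3)CCC2)ccc1/C=C/C(=O)OCOP(=O)(O)O`: 0.167 h

Both numbers come from an ADME assay (liver) for pharmacokinetics, with Liver microsome (Homo sapiens) as the target, using microsomes; a lower number here means that the compound disappears faster, a higher number that the compound lasts longer. Among the compounds with values here, compound 1 holds the higher of the two, and compound 2, its only neighbour so far, sits well under it. Within the data shown here, the one measured step is a 33-fold lower number from compound 1 to compound 2 (1.52 log units; beyond the scatter), large and beyond the scatter. It swaps the group on an oxygen next to a carbonyl group.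

Compound 3 `CCOc1cc(NC(=O)C2(NC(=O)c3ccc4c(C5CCCC5)c(-c5ncc(Cl)cn5)n(C)c4c3)CCC2)ccc1/C=C/C(=O)OCC(Cl)(Cl)Cl` is changed at that same place. The difference is 2,2,2-trichloroethyl in place of (2-carboxy-2-hydroxyethyl)carbonyl on an oxygen next to a carbonyl group: 2,2,2-trichloroethyl in place of (2-carboxy-2-hydroxyethyl)carbonyl.

Among the measured compounds shown here, the step to compound 2 is the only evidence that bears on this change, and it involves a different entering group, so it gives a rough guide only. For the measured compounds named here, no measured compound carries 2,2,2-trichloroethyl. With compound 1 at the top of the measured range at 5.57 h, a lower number is the likelier direction, probably by less than the step to compound 2. The expected step is a 5.6-fold lower number from compound 1 to compound 3 (0.75 log units; beyond the scatter), and this estimate is loose. For compound 3 the estimated half-life is 1 h, with an expected range of 0.2 h to 5.5 h.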

Compound 3, half-life: > 5 h
Compound 3 ended at the assay's limit; the forecaster's own chance of this, stated with the estimate: 10%; at least 5.0-fold (0.69 log units) between middle value and limit.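

In this assay compound 3 gives > 5 h, which is a limit of the assay and not a number. Even so, the position on an oxygen next to a carbonyl group tolerates the loss of (2-carboxy-2-hydroxyethyl)carbonyl without the collapse seen with compound 2: 2,2,2-trichloroethyl, which carries no hydrogen-bond donors or acceptors, gives an at least 29-fold higher number from compound 2 to compound 3 (1.47 log units; beyond the scatter), so a short half-life does not follow from every replacement at this place. The step between compound 1 and compound 3 cannot be read, so the two cannot be put in order, and the top of the series is bounded by the assay rather than resolved: the limit of > 5 h in this assay, at which 1 of the 3 values shown sits.

Still open, from the compounds shown here alone, is how far compound 3 really lies from compound 1, and whether its half-life depends on the chlorine atoms of 2,2,2-trichloroethyl or would hold for other groups without phosphorus. A plain ethyl group, a longer chain or a chain bearing an amine on the same oxygen would separate these readings, as would the free carboxylic acid.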